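The source may hold more compounds than are shown below. What is called first, only, known or untested is meant among the compounds shown, and "the series" means these compounds.

Four related compounds are compared in a physicochemical assay for acid dissociation. Compound 1 `CN(Cc1ccc(Cl)cc1)Cc1ccccc1CNc1ccnc2cc(Cl)ccc12` gives 7.44, and compound 2 `CN(Cc1ccccc1)Cc1ccccc1CNc1ccnc2cc(Cl)ccc12` gives 7.57. The change between them, (hydrogen in place of chloro on an aromatic carbon), gave a number 0.13 log units higher from compound 1 to compound 2 (within the scatter). Compound 3 `CN(Cc1ccc(Cl)cc1)Cc1ccc(CNc2ccnc3cc(Cl)ccc23)cc1` is built from the same atoms as compound 1 joined differently; the difference between the two cores is not broken down here. In this assay compound 3 gives 7.44. Compound 4 `CN(Cc1ccccc1)Cc1ccc(CNc2ccnc3cc(Cl)ccc23)cc1` has not yet been measured. It differs from compound 3 by hydrogen in place of chloro on an aromatic carbon, the same change that separates compound 1 from compound 2. Because a number 0.13 log units higher from compound 1 to compound 2 (within the scatter) stayed within the scatter, a similarly small step is expected here, a number 0.13 log units higher from compound 3 to compound 4 (within the scatter). Compound 4 is therefore expected to give 7.57, most likely between 7.3 and 7.85.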

Compound 4, acid dissociation constant: 7.56
Beside the measured number, compound 4's estimate is 0.01 log units above it; low and high end bracket the measured number.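

In this assay, putting hydrogen in place of chloro gave a number 0.12 log units higher from compound 3 to compound 4 (within the scatter) on one core and a number 0.13 log units higher from compound 1 to compound 2 (within the scatter) on the other, so the step stayed small on both cores shown. With both steps inside the scatter, this pair cannot show that the change has any real effect on the number, and two cores cannot show how it behaves on other cores in the series. Nothing measured here explains why the step is this small. The compounds shown carry only chloro or hydrogen at this place on the ring, which leaves open what fluoro, methoxy, an amine or a carboxylic acid would give there. From the compounds shown here alone, how the step behaves on a third core also remains open.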